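A Thioester Replaces an Amide: Expected Receptor Binding

The source may hold more compounds than are shown below. What is called first, only, known or untested is meant among the compounds shown, and "the series" means these compounds.

Of the compounds shown here, two sharing one core have been measured. Compound 1 `CC1=C(C(=O)OC(C)(C)C)C(c2ccoc2)NC(=O)N1` carries a tert-butoxy group on a carbonyl carbon; in an assay on membranes from HeLa cells for displacement of a labelled ligand from adenosine receptor A3 (Homo sapiens), read by scintillation counting, with a stated time of 180 min, tested at 1 uM (a higher number here means more inhibition at the concentration tested (going by the name of the read-out), a lower number less inhibition), compound 1 gives 2%. Compound 2 `CC1=C(C(=O)NC(C)C)C(c2ccoc2)NC(=O)N1` carries isopropylamino there instead, and in this assay compound 2 gives 3%. The step of a number 1 percentage points higher from compound 1 to compound 2 (within the scatter) is within the scatter, so the two cannot be told apart on these numbers, and compound 2 stands as one of two closely matching values, both low numbers in this assay. Compound 3 `CCSC(=O)C1=C(C)NC(=O)NC1c1ccoc1` differs from compound 2 as follows: ethylsulfanyl in place of isopropylamino on a carbonyl carbon. Among the compounds with values here, the only measured step that bears on this change, a number 1 percentage points higher from compound 1 to compound 2 (within the scatter), alters the same position and stayed within the scatter. No step beyond the scatter is therefore expected in this assay: no change at the digits printed from compound 2 to compound 3 (within the scatter). Compound 3 is estimated at 3%, with a range from -8% to 14%.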

Compound 3, a percentage reported as inhibition, at one concentration (the size of the read-out at that concentration, not a potency): 1%
Compound 3: middle estimate off by 2 percentage points, on the high side; the range from low to high includes it.
By their numbers in this assay, from the lowest: compounds 3, 1 and 2 (each within the scatter of the next).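

In this assay ethylsulfanyl brings sulfur to this carbonyl carbon, and the result stays within the scatter of both earlier compounds: a number 2 percentage points lower from compound 2 to compound 3 (within the scatter), and a number 1 percentage points lower from compound 1 to compound 3 (within the scatter). Groups joined through oxygen, nitrogen and sulfur therefore cannot be told apart at this position, and exchanging isopropylamino, with its hydrogen-bond donor, for ethylsulfanyl, which has none, gives no step beyond the scatter. Nothing available explains why these numbers lie so close together.

Going by these compounds, with all three numbers low, it remains open whether any group on this carbonyl carbon can raise the reading, as a carboxylic acid or a longer chain such as hexylsulfanyl might or might not. On these data alone, the shared core is also the same throughout, so the effect of a change elsewhere on it remains open too.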